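Methoxymethyl in Place of Methylphenyl: Cytotoxicity Outlook

The source may hold more compounds than are shown below. What is called first, only, known or untested is meant among the compounds shown, and "the series" means these compounds.

Compound 1, `COc1nc2ccccc2cc1/C=C/c1noc(-c2ccccc2)n1`: > 240000 nM
Compound 2, `COc1nc2ccccc2cc1/C=C/c1noc(-c2ccccc2C)n1`: > 230000 nM

Of the compounds shown here, two have been tested in an ADME assay on HepG2 cells (Homo sapiens) for cytotoxicity, read by sulforhodamine B assay, with a stated time of 48 h; on this read-out lower numbers stand for higher toxicity in this test and higher numbers for lower toxicity in this test. Compound 1 gives > 240000 nM, which is a limit of the assay and not a number. Compound 2 gives > 230000 nM, again only a limit. The step that the two limits leave unreadable from compound 1 to compound 2 cannot therefore be read in either direction, since the limit of > 230000 nM in this assay, at which 1 of the 2 values shown sits, and the limit of > 240000 nM in this assay, at which 1 of the 2 values shown sits, both sit at the edge of what the assay reports. Among the compounds with values here, compound 2 thus stands at a limit, and the one further value shown is a limit too.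

Compound 3, `COCc1nc(/C=C/c2cc3ccccc3nc2OC)no1`, differs from compound 2 by methoxymethyl in place of 2-methylphenyl on an aromatic carbon. Within the data shown here, no measured step bears on this change, and the single measured step is unreadable, so no direction can be drawn from the data. The expected step that the limit leaves unreadable from compound 2 to compound 3 is none beyond the scatter. Compound 3 is estimated at 240000 nM, within a range from 80000 nM to 400000 nM.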

Compound 3, half-maximal cytotoxic concentration: > 270000 nM
Compound 3: only a limit was reported; the forecaster's own chance of this, stated with the estimate: 75%; at least 1.1-fold (0.05 log units) between middle value and limit.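

In this assay compound 3 gives > 270000 nM, a limit of the assay and not a number. Within the data shown here, no step between compound 1, compound 2 and compound 3 can be read. Open remains whether any of the three changes in cytotoxicity with the group exchanged, and at what concentration each would become toxic.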